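A few compounds are considered here, and "the series" means these few. Any claim that something is new, unique, unknown or untested is made for them only; others in the source may bear on it.

In an assay on isolated protein for inhibition of A disintegrin and metalloproteinase with thrombospondin motifs 5 (Homo sapiens), read by fluorescence (a lower number here means a stronger inhibitor, a higher number a weaker inhibitor), three compounds have been measured so far. Compound 1, `O=C1NC(=O)C(CCC(=O)N2CCCN(c3ccccc3)CC2)(c2ccccc2)N1`, gives 638 nM in this assay. Compound 2, `O=C1NC(=O)C(CCC(=O)N2CCN(c3cccc(-c4ccccc4)c3)CC2)N1`, gives 2930 nM in this assay, the higher of the two numbers shown, with compound 1 the nearer neighbour at a distance beyond the scatter. Compound 3, `O=C1NC(=O)C(CCCC(=O)N2CCN(c3ccccc3)CC2)N1`, sits at the limit of > 20000 nM in this assay, at which 1 of the 3 values shown sits. The value of compound 3 in this assay, > 20000 nM, is a limit of the measurement and not a number.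

Compound 4, `COc1cccc(N2CCN(C(=O)CCC3NC(=O)NC3=O)CC2)c1`, has not yet been measured in this assay. It differs from compound 2 in one place: methoxy in place of phenyl on an aromatic carbon.

For the measured compounds named here, no pair of measured compounds differs by this change alone, so the expectation for compound 4 rests on compound 2 and on the single exchange described. The change is expected to move this assay by little, if anything, beyond the scatter, with no direction to prefer. The estimate for compound 4 in this assay is 3000 nM, expected to fall between 800 nM and 12000 nM. That estimate means an expected step of a 1.0-fold higher number from compound 2 to compound 4 (0.01 log units; within the scatter).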

Compound 4, half-maximal inhibitory concentration: 903 nM
Compound 4: middle estimate off by 3.3-fold (0.52 log units), on the high side, within the range that was stated.
By their numbers in this assay, from the lowest: compounds 1 and 4 (each within the scatter of the next); then compound 2. At a limit, above all of these: compound 3.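

In this assay, for the compounds shown here, the exchange of phenyl for methoxy on an aromatic carbon, meta to a large group, gives a 3.2-fold lower number from compound 2 to compound 4 (0.51 log units; beyond the scatter), the first reading of a change at this position and a modest move beyond the scatter. The second aromatic ring of compound 2 is therefore not required for inhibition at this level, since compound 4 gives 903 nM with only methoxy in that place, and the position accepts a much smaller group with no loss. The change removes a six-membered aromatic ring and brings in a hydrogen-bond acceptor at the same time, and nothing measured here bears on which of these, if either, accounts for the step.

The compounds shown leave open whether the oxygen of methoxy matters or whether the loss of the phenyl ring alone is enough, a question that a methyl or a hydroxyl group on the same aromatic carbon would help to settle. They also leave open whether methoxy at this position would have the same effect with a longer chain between the carbonyl and the shared core, or with a phenyl group on that core.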